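Swapping an Acetyl for a Methyl(phenyl)carbamoyl Group

A few compounds are considered here, and "the series" means these few. Any claim that something is new, unique, unknown or untested is made for them only; others in the source may bear on it.

For the measured compounds named here, only two compounds have been measured so far in a functional assay on MKN-45 cells (Homo sapiens) for cytotoxicity; a higher number here means a weaker inhibitor, a lower number a stronger inhibitor. There, compound 1 (`COc1ccc(S(=O)(=O)N2CCc3cccc(NC(C)=O)c32)cc1`) gives 61 nM and compound 2 (`COc1ccc(S(=O)(=O)N2CCc3cc(Br)cc(NC(=O)c4ccncc4)c32)cc1`) gives 86 nM. Going by the values given here, these two numbers lie within the scatter of each other, so compound 1 sits level with the only other measured compound, and neither can be ranked above the other.

The next compound, compound 3 (`COc1ccc(S(=O)(=O)N2CCc3cccc(NC(=O)N(C)c4ccccc4)c32)cc1`), keeps the shared core of compound 1 and changes it in one place: methyl(phenyl)amino in place of methyl on a carbonyl carbon. Put simply, methyl(phenyl)amino takes the place of methyl on a carbonyl carbon, which turns the acetyl into methyl(phenyl)carbamoyl and brings in a new aromatic ring.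

Among the compounds with values here, no measured pair of compounds shows what a change of this kind does, so any forecast is uncertain. A modest shift towards a weaker inhibitor seems more likely than a gain, and the expected change is a 2.1-fold higher number from compound 1 to compound 3 (0.33 log units; beyond the scatter). For compound 3 the estimated value is 130 nM, with an expected range of 25 nM to 700 nM.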

Compound 3, half-maximal inhibitory concentration: > 10000 nM
Compound 3 ended at the assay's limit (the forecaster's own chance of this, stated with the estimate: 5%); at least 76-fold (1.88 log units) between middle value and limit.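

In this assay, putting methyl(phenyl)amino in place of methyl on a carbonyl carbon gives an at least 160-fold higher number from compound 1 to compound 3 (2.21 log units; beyond the scatter), the first step measured at this place and a large one. For the compounds shown here, compound 3 gives > 10000 nM, which is a limit of the assay and not a number: the limit of > 10000 nM in this assay, at which 1 of the 3 values shown sits. What the earlier compounds could not show is that this place on the shared core does not accept every group, since the acetyl of compound 1 goes with a low number and the methyl(phenyl)carbamoyl of compound 3 does not; compound 2 differs from both in more than one place, so it cannot be compared with either here.

From the compounds shown here alone, it remains open which part of the larger group goes with this loss, the phenyl ring or the methyl on its nitrogen, or the nitrogen itself. A plain amino group, a dimethylamino group or an ethyl chain on the same carbonyl carbon would help to show how much larger than methyl the group can become before the number climbs to the limit.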